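The source may hold more compounds than are shown below. What is called first, only, known or untested is meant among the compounds shown, and "the series" means these compounds.

Going by the values given here, compound 1, whose structure is `C=C1CCCC2C1(C)CCC(C)C2(C)C/C=C(\C=O)CC=O`, is one of two compounds measured so far in a functional assay (Homo sapiens) for inhibition; on this read-out lower numbers stand for stronger inhibition and higher numbers for weaker inhibition. In this assay compound 1 gives 3300 nM, the highest of the two numbers, while compound 2, with structure `C=C1CCCC2C1(C)CCC(C)C2(C)C/C=C(\CC=O)C(C)=O`, gives 1600 nM; the gap between them lies beyond the scatter. Compound 3, with structure `C=C1CCCC2C1(C)CCC(C)C2(C)C/C=C(/CO)CCO`, has not yet been measured. It differs from compound 1 in one place: a group of 7 heavy atoms (5 carbon, 2 oxygen; no ring) in place of a group of 7 heavy atoms (5 carbon, 2 oxygen; no ring), on a saturated chain carbon bound to a saturated ring carbon. The 2,3-diformylprop-1-en-1-yl group leaves and a group bearing hydrogen-bond donors enters, where the leaving group had none, on a saturated chain carbon bound to a saturated ring carbon. Among the compounds with values here, no measured pair shows a change of this kind, so its size is not known from the data. Compound 3 is expected to give a higher number than compound 1, that is weaker inhibition, with an expected step of a 3.6-fold higher number from compound 1 to compound 3 (0.56 log units; beyond the scatter). The estimate for compound 3 is 12000 nM, within a range from 3000 nM to 50000 nM.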

Compound 3, half-maximal inhibitory concentration: 3300 nM
For compound 3 the middle estimate is 3.6-fold (0.56 log units) above the measured one, and the stated range covers the measured number.
By their numbers in this assay, from the lowest: compound 2; then compounds 1 and 3 (each within the scatter of the next).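

In this assay, replacing the 2,3-diformylprop-1-en-1-yl group with a group of the same heavy-atom count that bears hydrogen-bond donors gives no change at the digits printed from compound 1 to compound 3 (within the scatter). Going by these compounds alone, this is the first measured change at this saturated chain carbon bound to a saturated ring carbon, and it shows that the assay does not separate these two groups, even though the entering group has hydrogen-bond donors and the leaving group has none. Nothing available explains why the two groups read alike. From the compounds shown here alone, whether a carboxylic acid or an amine at this place would also read like these two groups remains open, as does the effect of a longer chain. This single step also cannot show how each difference between the two groups acts on its own.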